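The source may report more compounds than this note shows. Statements on the series, on what has been measured and on what is new or still open speak of the compounds shown alone.

Series notes. Three analogues of a shared core have numbers in a functional assay on A-375 cells (Homo sapiens) for antiproliferative activity, read by CCK-8 assay, with a stated time of 72 h, tested at 2 uM; a lower number here means a weaker effect, a higher number a stronger effect of the compound at the concentration tested. Compound 1 `Nc1ccccc1NC(=O)c1ccc(CSC(=S)N2CCc3cc([N+](=O)[O-])ccc32)cc1` gives 16.9% in this assay. Compound 2 `Nc1ccccc1NC(=O)c1ccc(CSC(=S)N2CCN(C(c3ccccc3)c3ccccc3)CC2)cc1` gives 8.7% in this assay. Compound 3 `Nc1ccccc1NC(=O)c1ccc(CSC(=S)N2CCN(c3ccncc3)CC2)cc1` gives 85.7% in this assay, the highest of the three; its nearest neighbour on the numbers is compound 1, lower by a margin beyond the scatter, and compound 2 lies further below, also beyond the scatter. Within the data shown here, no two of the measured compounds differ in a single place, so no single-point step between them can be read.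

Compound 4 `CN1CCN(C(=S)SCc2ccc(C(=O)Nc3ccccc3N)cc2)CC1` has not been measured in this assay. It differs from compound 3 as follows: methyl in place of pyridin-4-yl on an amine nitrogen in a ring. The methyl takes the place of the pyridin-4-yl on the amine nitrogen in the ring; what remains is the shared core. With the two other amine-substituted analogues, compound 1 and compound 2, sitting far below compound 3, a step downward beyond the scatter is expected for a number 45.7 percentage points lower from compound 3 to compound 4 (beyond the scatter). For compound 4 an inhibition of 40% is estimated, with a range from 10% to 80%.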

Compound 4, a percentage reported as inhibition, at one concentration (the size of the read-out at that concentration, not a potency): 36.6%
Beside the measured number, compound 4's estimate is 3.4 percentage points above it; measured number inside the range.
By their numbers in this assay, from the lowest: compounds 2 and 1 (each within the scatter of the next); then compound 4; then compound 3.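

Among these compounds, the first single-place step falls on the amine nitrogen in the ring: in this assay, methyl in place of pyridin-4-yl gives a number 49.1 percentage points lower from compound 3 to compound 4 (beyond the scatter) and is read as a large change. This position therefore responds strongly to its substituent while the shared core stays fixed, and the high number of compound 3 depends on the pyridin-4-yl. The change removes a six-membered aromatic ring and its ring nitrogen together, so this one step cannot separate the ring from the nitrogen, and no measurement shown gives a cause for the step.

Still open, on these data alone, is whether phenyl, which lacks the ring nitrogen, or pyridin-3-yl, which moves it, would keep the number of compound 3. Also open, as far as these compounds go, is how an ethyl or benzyl group on this nitrogen would compare with the methyl of compound 4.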